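The compounds below may be only part of what the source reports. "The series", "measured", "known", "first", "only" and "open" are said of these compounds alone.

Of the compounds shown here, three have so far been measured in an assay on HEK293 cells for agonist activity at transient receptor potential cation channel subfamily M member 8 (Homo sapiens), read by fluorescence and calcium flux, with a stated time of 15 min; a lower number here means that less compound is needed, a higher number that more compound is needed for the effect. Compound 1 `Cc1ccc(OCC(=O)N(CCO)Cc2cccs2)cc1` gives 900 nM in this assay. Compound 2 `CCN(Cc1cccs1)C(=O)c1cc2cc(C)ccc2[nH]1`, which is built on a different core, gives 2010 nM, and compound 3 `CCN(Cc1cccs1)C(=O)COc1cccc(C)c1` gives 97 nM. Among these three numbers compound 1 stands second highest: compound 2 is its nearest neighbour, with a higher number, and compound 3 is the furthest away, with a lower number, and both gaps lie beyond the usual scatter of repeated measurements.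

Compound 4 `Cc1ccc(OCC(=O)N(Cc2cccs2)C(C)(C)C)cc1` has not yet been measured. It differs from compound 1 in a single place: tert-butyl in place of 2-hydroxyethyl on an amide-type nitrogen. Within the data shown here, no pair among the measured compounds differs in just this one place, so the size of this step cannot be read directly from the data. Compound 3 also carries a plain alkyl group without a hydroxyl on its amide nitrogen and shows a lower number than compound 1, but it differs from compound 1 elsewhere as well, so that pair gives only a hint, not a measured step.

On that hint, compound 4 is expected to move toward a lower number, with the step of a 2.3-fold lower number from compound 1 to compound 4 (0.35 log units; beyond the scatter) of modest size, likely at or just beyond the scatter. Compound 4 is therefore estimated at 400 nM, with a plausible range from 100 nM to 2000 nM.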

Compound 4, half-maximal effective concentration: 11000 nM
For compound 4 the middle estimate is 28-fold (1.44 log units) below the measured one; the measured number lies above the stated range.
By their numbers in this assay, from the lowest: compound 3; then compound 1; then compound 2; then compound 4.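

Putting tert-butyl in place of 2-hydroxyethyl on the amide-type nitrogen gives a 12-fold higher number from compound 1 to compound 4 (1.09 log units; beyond the scatter) in this assay, so this is a large step and the first one measured at this position. It shows that the group on this nitrogen can change the number strongly, and that removing the hydroxyl does not by itself bring a lower number: this swap takes away the hydrogen-bond donor and acceptor of 2-hydroxyethyl and ends with a higher number. Nothing measured here explains why the number rises so sharply.

A single swap changes several things at once, so the compounds shown leave open whether the loss of the hydroxyl, the branching of tert-butyl or the extra heavy atom matters most. An unbranched butyl chain or a 2-methoxyethyl group on the same nitrogen of the core of compound 1 would begin to separate these, since the first keeps the carbon count of tert-butyl without its branching and the second keeps the oxygen of 2-hydroxyethyl without its hydrogen.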